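Removing the fluorine from the pyridine arm

This account rests on a few compounds, and the source may have more. Where it says the series, first, only, none or still open, it means among the compounds named here.

Compound 1 `CS(=O)(=O)Nc1ccc2c(c1)S(=O)(=O)N=C(C1=C(O)C3CCCC3N(Cc3ccc(F)cn3)C1=O)N2` was examined in an in vitro ADME assay on microsomes from liver (Homo sapiens) for metabolic stability; a higher number here means that the compound lasts longer, a lower number that the compound disappears faster. In this assay compound 1 gives > 1 h, which is a limit of the assay rather than a number. Compound 2 `CS(=O)(=O)Nc1ccc2c(c1)S(=O)(=O)N=C(C1=C(O)C3CCCCCCC3N(Cc3ccc(F)cc3)C1=O)N2` gives > 1 h in this assay, also a limit. Compound 3 `CS(=O)(=O)Nc1ccc2c(c1)S(=O)(=O)N=C(C1=C(O)C3CCCCC3N(Cc3ccc(F)cc3)C1=O)N2` gives > 1 h in this assay, again a limit. Compound 1 thus stands at the limit of > 1 h in this assay, at which 3 of the 3 values shown sit, and no ordering among the three compounds can be drawn from these values.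

Compound 4 `CS(=O)(=O)Nc1ccc2c(c1)S(=O)(=O)N=C(C1=C(O)C3CCCC3N(Cc3ccccn3)C1=O)N2` has not yet been measured in this assay. It differs from compound 1 in one place: hydrogen in place of fluoro on an aromatic carbon, so that the (5-fluoropyridin-2-yl)methyl group becomes (pyridin-2-yl)methyl. Among the compounds with values here, no step of this kind between measured compounds is available, so the size of the effect can only be expected. Because compound 1 sits at the limit > 1 h, a shift in either direction may stay hidden behind that limit. The step from compound 1 to compound 4 is estimated as a step that the limit leaves unreadable from compound 1 to compound 4, a change not beyond the scatter. Compound 4 is expected to give 1.2 h in this assay, with a likely range from 0.5 h to 3 h.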

Compound 4, half-life: > 1 h
Compound 4 was reported as a limit; the forecaster's own chance of this, stated with the estimate: 60%; the middle value does not contradict the limit.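

In this assay compound 4 gives > 1 h, which is a limit of the assay and not a number. Compound 1 also stands at a limit, so no step from compound 1 to compound 4 can be read: the limit of > 1 h in this assay, at which 4 of the 4 values shown sit.

The compounds shown leave open whether the (5-fluoropyridin-2-yl)methyl and (pyridin-2-yl)methyl groups differ at all in this assay.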